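A Trimethoxyphenyl Swap Repeated on a Methylated Core

The source may hold more compounds than are shown below. What is called first, only, known or untested is meant among the compounds shown, and "the series" means these compounds.

Compound 1 `CCOC(=O)c1sc2ccc(NCc3c[nH]cn3)cc2c1NC(=O)c1ccc(C)cc1` and compound 3 `CCOC(=O)c1sc2ccc(NCc3nc[nH]c3C)cc2c1NC(=O)c1ccc(C)cc1` share a core that differs only in methyl in place of hydrogen on an aromatic carbon. In a functional assay on HeLa cells (Homo sapiens) for antiproliferative activity, read by MTT assay, with a stated time of 48 h (on this read-out higher numbers stand for weaker inhibition of growth and lower numbers for stronger inhibition of growth), compound 1 gives 11700 nM, and in this assay compound 3 gives 11400 nM, a step of a 1.0-fold lower number from compound 1 to compound 3 (0.01 log units; within the scatter). Compound 2 `CCOC(=O)c1sc2ccc(NCc3c[nH]cn3)cc2c1NC(=O)c1cc(OC)c(OC)c(OC)c1` arises from compound 1 through the change (3,4,5-trimethoxyphenyl in place of 4-methylphenyl on a carbonyl carbon); in this assay compound 2 gives 6790 nM, which is a 1.7-fold lower number from compound 1 to compound 2 (0.24 log units; within the scatter). Compound 4 `CCOC(=O)c1sc2ccc(NCc3nc[nH]c3C)cc2c1NC(=O)c1cc(OC)c(OC)c(OC)c1`, not yet measured, arises from compound 3 through the same change, (3,4,5-trimethoxyphenyl in place of 4-methylphenyl on a carbonyl carbon), at a place described in the same words. The step of a 1.7-fold lower number from compound 3 to compound 4 (0.23 log units; within the scatter) in this assay is expected to be of about the same size as the earlier one, because a 1.7-fold lower number from compound 1 to compound 2 (0.24 log units; within the scatter) was modest. Compound 4 is therefore estimated at 6700 nM in this assay, with a likely range from 3000 nM to 15000 nM.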

Compound 4, concentration for 50% growth inhibition: 2230 nM
Compound 4: middle estimate off by 3.0-fold (0.48 log units), on the high side; the measured number lies below the stated range.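

In this assay the swap to 3,4,5-trimethoxyphenyl on a carbonyl carbon gave a 5.1-fold lower number from compound 3 to compound 4 (0.71 log units; beyond the scatter) and so did not carry over at its earlier size to the methylated core: the same change on two cores in this assay, a 1.7-fold lower number (0.24 log units; within the scatter) from compound 1 to compound 2 and a 5.1-fold lower number (0.71 log units; beyond the scatter) from compound 3 to compound 4, 3.0-fold (0.47 log units) apart, beyond the scatter of two such steps. Read the other way, methyl in place of hydrogen on an aromatic carbon gave a 3.0-fold lower number from compound 2 to compound 4 (0.48 log units; beyond the scatter) and so also depended on the group already present: the same change on two cores in this assay, a 1.0-fold lower number (0.01 log units; within the scatter) from compound 1 to compound 3 and a 3.0-fold lower number (0.48 log units; beyond the scatter) from compound 2 to compound 4, 3.0-fold (0.47 log units) apart, beyond the scatter of two such steps. These four compounds show that the two changes do not simply add up, but they do not show why, or whether this holds on any other core.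

On these data alone, it remains open whether the same dependence would appear with a carboxylic acid in place of the ethyl ester. The same question applies to a longer chain in place of the added methyl.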